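The source may report more compounds than this note shows. Statements on the series, on what has been measured and on what is new or still open speak of the compounds shown alone.

Of the compounds shown here, three have so far been measured in an ADME assay on microsomes from liver (Mus musculus) for metabolic stability; a higher number here means faster removal of the compound, a lower number slower removal. Compound 1 (`Oc1c(-c2nnc(Cc3ccc(Cl)cc3)[nH]2)ncc2cccnc12`) gives 16 mL.min-1.g-1, compound 2 (`COc1ccccc1-c1ccnc2c(O)c(-c3nc(C)n[nH]3)ncc12`) gives 0.8 mL.min-1.g-1, and compound 3 (`O=C(NCc1ccc(F)cc1)c1ncc2c(N3CCCCS3(=O)=O)cccc2c1O`) gives 2 mL.min-1.g-1. Compound 3 therefore holds the middle place, and its gaps to the other two both lie beyond the scatter, with compound 2 the nearer neighbour.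

The next compound to be tested is compound 4 (`O=C(NCc1ccc(F)cc1)c1ncc2c(NC3CCOCC3)cccc2c1O`), which matches compound 3 except for one group on an aromatic carbon. The change is a group of 7 heavy atoms (5 carbon, 1 nitrogen, 1 oxygen; one six-membered non-aromatic ring with 1 hetero atom) in place of a group of 8 heavy atoms (4 carbon, 1 nitrogen, 2 oxygen, 1 sulfur; one six-membered non-aromatic ring with 2 hetero atoms), on an aromatic carbon. The incoming group is (oxan-4-yl)amino, and it sits on the same six-membered aromatic ring of carbon only.

Among the compounds with values here, no two measured compounds differ in just one place, so no measured step shows what this exchange does, and any forecast is uncertain. A modest rise seems more likely than a fall, somewhat beyond the scatter. Compound 3 sits low at 2 mL.min-1.g-1, while compound 1 at 16 mL.min-1.g-1 shows that much higher numbers occur among these compounds. The expected change is an estimated step of a 2.5-fold higher number from compound 3 to compound 4 (0.40 log units; beyond the scatter). The estimate for compound 4 is 5 mL.min-1.g-1, with an expected range from 1.5 mL.min-1.g-1 to 15 mL.min-1.g-1.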

Compound 4, intrinsic clearance in microsomes in the Mus musculus assay: 2.2 mL.min-1.g-1
Beside the measured number, compound 4's estimate is 2.3-fold (0.36 log units) above it, and the stated range covers the measured number.
By their numbers in the Mus musculus assay, from the lowest: compound 2; then compounds 3 and 4 (each within the scatter of the next); then compound 1.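

Within the data shown here, in the Mus musculus assay compound 3 gives 2 mL.min-1.g-1 and compound 4 gives 2.2 mL.min-1.g-1; this is the first pair of compounds that differ in one place, and it gives a 1.1-fold higher number from compound 3 to compound 4 (0.04 log units; within the scatter). On this aromatic carbon, then, the assay does not tell the (oxan-4-yl)amino group apart from the six-membered non-aromatic ring it replaces, even though the incoming group carries a hydrogen-bond donor and the leaving group has none, and the leaving group has double bonds outside aromatic rings that the incoming one lacks. Nothing available explains why this exchange leaves the number within the scatter.

In a physicochemical assay for lipophilicity, at pH 7.4 (a lower number here means a more polar compound, a higher number a more lipophilic compound), compound 4 gives 5.3, but compound 3 is recorded as "not determined" (no result reported), so the step for this exchange cannot be read in that assay. Going by these compounds, one exchange on a single core also says little about this position as a whole, and it remains open whether a simple amine, a carboxylic acid or a longer chain on the same aromatic carbon would also stay within the scatter of these two compounds in the Mus musculus assay.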